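Removing the dimethylamino group from compound 1

The source may report more compounds than this note shows. Statements on the series, on what has been measured and on what is new or still open speak of the compounds shown alone.

Compound 1 `CN(C)c1ccc(/C=C2\CCC/C(=C\c3ccccc3[N+](=O)[O-])C2=O)cc1`: 168000 nM
Compound 2 `CN(C)c1ccc(/C=C2\CCC/C(=C\c3ccc([N+](=O)[O-])cc3)C2=O)cc1`: > 500000 nM
Compound 3 `O=C1/C(=C/c2ccc(Cl)cc2)CCC/C1=C\c1cccc([N+](=O)[O-])c1`: 1750 nM

In a functional assay on CCRF-CEM cells (Homo sapiens) for cytotoxicity, with a stated time of 72 h (on this read-out lower numbers stand for stronger inhibition and higher numbers for weaker inhibition), compound 1 gives 168000 nM, the highest of the two numbers shown. For compound 2 the result is only an assay limit, > 500000 nM. Compound 3 gives 1750 nM, the lowest number shown.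

Compound 4 `O=C1/C(=C/c2ccccc2)CCC/C1=C\c1ccccc1[N+](=O)[O-]` differs from compound 1 by hydrogen in place of dimethylamino on an aromatic carbon. Going by the values given here, the only single-change step measured, an at least 2.9-fold higher number from compound 1 to compound 2 (0.47 log units; beyond the scatter), moves the nitro group and does not touch the dimethylamino group, so no measured step bears on this change. Compound 3, which carries no dimethylamino group, shows the far lower number. Compound 4 is therefore expected to give a lower number, estimated at 15000 nM, between 3000 nM and 80000 nM, a step of an 11-fold lower number from compound 1 to compound 4 (1.05 log units; beyond the scatter).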

Compound 4, half-maximal inhibitory concentration: 925 nM
Estimate against measurement, compound 4: 16-fold (1.21 log units) above; the measured number lies below the stated range.
By their numbers in this assay, from the lowest: compounds 4 and 3 (each within the scatter of the next); then compound 1. At a limit, above all of these: compound 2.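

In this assay, going by these compounds alone, the change from 4-(dimethylamino)phenyl to phenyl gives a 180-fold lower number from compound 1 to compound 4 (2.26 log units; beyond the scatter), the first measured step at this position; the only earlier step moved the nitro group instead. With the 2-nitrophenyl held fixed, what sits on this aromatic carbon, para to a large group, therefore strongly changes the read-out. Nothing shown here explains the size of this step. Going by these compounds, whether an amino or methoxy group on this carbon would give a number nearer compound 4 or compound 1 remains open. So does whether hydrogen in place of dimethylamino would shift compound 2 in the same way.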